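Epimer at the chain carbon: compound 3 to compound 4

The source may hold more compounds than are shown below. What is called first, only, known or untested is meant among the compounds shown, and "the series" means these compounds.

Compound 3 `Cc1ccc(-c2ccc(C(=O)N[C@H](c3nc(C)c(CO)s3)[C@@H]3CCCCN3)[nH]2)cc1F` gives 18000 nM in a toxicity assay on TZM cells (Homo sapiens) for cytotoxicity, read by XTT assay, with a stated time of 3 days; on this read-out lower numbers stand for higher toxicity in this test and higher numbers for lower toxicity in this test. This is the largest of the three numbers, yet the gap to compound 2 `Cc1nc([C@H](NC(=O)c2ccc(-c3ccc(Cl)c(F)c3)[nH]2)[C@H]2CCCCN2)sc1CO` with 17400 nM and to compound 1 `Cc1nc([C@@H](NC(=O)c2ccc(-c3ccc(Cl)c(F)c3)[nH]2)[C@H]2CCCCN2)sc1CO` with 15200 nM is within the scatter, so the three compounds are indistinguishable here. Compound 4 `Cc1ccc(-c2ccc(C(=O)N[C@@H](c3nc(C)c(CO)s3)[C@@H]3CCCCN3)[nH]2)cc1F` differs from compound 3 only in that (the two compounds have the same atoms and bonds and differ only in configuration as drawn: 1 of 2 stereo elements differ; a stereocentre at a saturated chain carbon is drawn S in compound 3 and R in compound 4). Within the data shown here, one measured step bears on this: a 1.1-fold higher number from compound 1 to compound 2 (0.06 log units; within the scatter), a pair that, because of the fact that compounds 1 and 2 differ only in the configuration as drawn, shares the same change of configuration as drawn. That step did not leave the scatter, so for compound 4 no shift beyond the scatter is expected, meaning no change at the digits printed from compound 3 to compound 4 (within the scatter). Compound 4 is therefore estimated at 18000 nM in this assay, with a range from 9000 nM to 36000 nM.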

Compound 4, half-maximal cytotoxic concentration: 19200 nM
For compound 4 the middle estimate is 1.1-fold (0.03 log units) below the measured one; the range from low to high includes it.
By their numbers in this assay, from the lowest: compounds 1, 2, 3 and 4 (each within the scatter of the next).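

In this assay, the change from S to R at the chain carbon gives a 1.1-fold higher number from compound 3 to compound 4 (0.03 log units; within the scatter), so a second pair now shows no readable effect of configuration at this position. The finding therefore no longer rests on compounds 1 and 2 alone, and the pair behind it differs in this one place only: the fact that compounds 3 and 4 differ only in the configuration as drawn

On these data alone, whether this holds once a carboxylic acid or a longer chain is carried on the shared core stays open. As far as these compounds go, the other stereocentre also stays open, as neither pair differs there.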